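A few compounds are considered here, and "the series" means these few. Any claim that something is new, unique, unknown or untested is made for them only; others in the source may bear on it.

Compound 1 (`O=[N+]([O-])c1ccc(Nc2nc3c(N4CCCC4)ncnc3s2)cc1`): > 10000 nM in a functional assay on CHO-K1 cells for antagonist activity at adenosine receptor A2b (Homo sapiens), read by 33P incorporation, with a stated time of 20 min, in the presence of a further agent that is not named here; a higher number here means a weaker inhibitor, a lower number a stronger inhibitor.
Compound 2 (`Fc1cccc(F)c1Nc1nc2c(Cl)ncnc2s1`): > 10000 nM in this assay.
Compound 3 (`Clc1ncnc2sc(Nc3cccc(Br)c3)nc12`): > 10000 nM in this assay.

Each of these three values is a limit of this assay and not a number. Compound 1 stands at the limit of > 10000 nM in this assay, at which 3 of the 3 values shown sit. With every measured compound sitting at the same limit, the measured set offers no step beyond the scatter from which a trend could be read.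

Compound 4 (`Cc1ccc(Nc2nc3c(N4CCCC4)ncnc3s2)cc1`) differs from compound 1 in one place: methyl in place of nitro on an aromatic carbon of a six-membered aromatic ring of carbon only, para to a large group. The shared core is otherwise unchanged.

Because compound 1 shows only > 10000 nM, no direction can be derived for this change from the data shown. The step from compound 1 to compound 4 in this assay is expected to be a number no higher from compound 1 to compound 4 (the limit leaves the size open), which is to say no resolved movement beyond the scatter. Compound 4 is therefore estimated at 10000 nM in this assay, within a range from 3000 nM to 30000 nM, with a real chance that the assay again reports only a limit.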

Compound 4, inhibition constant: > 10000 nM
Compound 4 ended at the assay's limit (the forecaster's own chance of this, stated with the estimate: 65%); the middle value lies on the limit itself.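

Compound 1 and compound 4 both sit at a limit of this assay and not at a number, so no step can be read for methyl in place of nitro on an aromatic carbon. The compounds shown leave open which structural change, if any, would give a measurable value: the limit of > 10000 nM in this assay, at which 4 of the 4 values shown sit.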